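Same Atoms, Joined Differently: From Compound 3 to Compound 4

The source may hold more compounds than are shown below. What is called first, only, known or untested is meant among the compounds shown, and "the series" means these compounds.

Among the measured compounds shown here, in a physicochemical assay for solubility (on this read-out higher numbers stand for higher solubility and lower numbers for lower solubility), compound 3 `CNC(=O)c1cc(C(=O)NC2CC2)cn(Cc2nccc3[nH]ccc23)c1=O` gives 73 ug/mL as the only true number among the values at hand. Compound 1 `CNC(=O)c1cc(C(=O)NCCCC2CNCCO2)cn(Cc2ccccc2)c1=O` stands at >= 194 ug/mL and this is a limit of the assay, not a number. Compound 2 `CCNC(=O)c1cc(C(=O)NC)c(=O)n(Cc2ccccc2)c1` stands at >= 144 ug/mL and this too is a limit.

The unmeasured compound 4 `CNC(=O)c1cc(C(=O)NC2CC2)cn(Cc2ccc3nc[nH]c3c2)c1=O` differs from compound 3 as follows: a group of 9 heavy atoms (7 carbon, 2 nitrogen; one five-membered aromatic ring with 2 hetero atoms, one six-membered aromatic ring of carbon only) in place of a group of 9 heavy atoms (7 carbon, 2 nitrogen; one five-membered aromatic ring with 1 hetero atom, one six-membered aromatic ring with 1 hetero atom), on a saturated chain carbon bound to an aromatic nitrogen and the two hold the same atoms, joined differently. For the measured compounds named here, the only measured step is a step that the two limits leave unreadable from compound 1 to compound 2 and it gives little help. Its size cannot be read, and it lies at a different place from this change. With nothing pointing up or down, no step beyond the usual scatter is expected in this assay for this swap. The estimate therefore starts from compound 3 at 73 ug/mL and stays close to it. The expected step is a 1.0-fold lower number from compound 3 to compound 4 (0.02 log units; within the scatter) in size. For compound 4 the estimated value is 70 ug/mL with an expected range from 25 ug/mL to 190 ug/mL in repeat measurements.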

Compound 4, solubility: >= 163 ug/mL
Compound 4 ended at the assay's limit; the forecaster's own chance of this, stated with the estimate: 15%; at least 2.3-fold (0.36 log units) between middle value and limit.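

Swapping the old two-ring group for 1H-benzimidazol-6-yl on a saturated chain carbon bound to an aromatic nitrogen keeps the same atoms, joined differently, yet in this assay it gives an at least 2.2-fold higher number from compound 3 to compound 4 (0.34 log units; beyond the scatter). The only earlier step cannot be read and lies at a different place, so this is the first sign among the compounds shown that the read-out responds to a change at this place, even with the hydrogen-bond donor and acceptor counts of the two groups the same. The full size of the step stays unknown because compound 4 gives a limit of the assay, not a number: the limit of >= 163 ug/mL in this assay, at which 1 of the 4 values shown sits.

From the compounds shown here alone, how far compound 4 truly lies past that limit remains open. Also open, going by these compounds, is whether a quinoline group at this place, or an amine or a carboxylic acid added to the 1H-benzimidazol-6-yl group, would move the number further in this assay.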